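Replacing the 2-methoxyphenyl of compound 3

The source may hold more compounds than are shown below. What is called first, only, known or untested is meant among the compounds shown, and "the series" means these compounds.

Compound 1 `COc1ccc(C(=O)/C=C/c2ccc(N(C)C)cc2)c2c1C=CC(C)(C)O2`: 2750 nM
Compound 2 `COc1ccc(C(=O)/C=C/c2ccccc2Cl)c2c1C=CC(C)(C)O2`: > 10000 nM (a limit)
Compound 3 `COc1ccccc1/C=C/C(=O)c1ccc(OC)c2c1OC(C)(C)C=C2`: > 10000 nM (a limit)

In a functional assay on SK-OV-3 cells (Homo sapiens) for antiproliferative activity, read by MTT assay, with a stated time of 24 h (a higher number here means a weaker inhibitor, a lower number a stronger inhibitor), compound 3 gives only a limit, > 10000 nM, and no number. Compound 2 shares that limit, as the limit of > 10000 nM in this assay, at which 2 of the 3 values shown sit, records. Compound 4 `COc1ccc(C(=O)/C=C/c2cc(Cl)ccc2O)c2c1C=CC(C)(C)O2` carries this change: 5-chloro-2-hydroxyphenyl in place of 2-methoxyphenyl on a double-bonded chain carbon bound to a double-bonded chain carbon. Among the measured compounds shown here, two measured steps bear on it: an at least 3.6-fold higher number from compound 1 to compound 3 (0.56 log units; beyond the scatter) and an at least 3.6-fold higher number from compound 1 to compound 2 (0.56 log units; beyond the scatter). Both lie beyond the scatter, and both leave the 4-(dimethylamino)phenyl group. The step that the two limits leave unreadable from compound 2 to compound 3 cannot be read. For the measured compounds named here, no measured compound carries the 5-chloro-2-hydroxyphenyl group, so only a small gain in this assay, if any, is expected. The expected change is an at least 1.2-fold lower number from compound 3 to compound 4 (0.09 log units; that floor lies within the scatter). Compound 4 is estimated at 8000 nM, within an expected range of 3000 nM to 20000 nM.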

Compound 4, half-maximal inhibitory concentration: 6270 nM
Estimate against measurement, compound 4: 1.3-fold (0.11 log units) above, within the range that was stated.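

Compound 4 gives a number in this assay, the only one shown at this place without the 4-(dimethylamino)phenyl group. Compound 2 and compound 3 stay at a limit: the limit of > 10000 nM in this assay, at which 2 of the 4 values shown sit. The gain is only a floor, an at least 1.5-fold lower number from compound 3 to compound 4 (0.20 log units; that floor lies within the scatter) and an at least 1.5-fold lower number from compound 2 to compound 4 (0.20 log units; that floor lies within the scatter), while the 4-(dimethylamino)phenyl group keeps its lead, with a 2.3-fold higher number from compound 1 to compound 4 (0.36 log units; beyond the scatter).

The hydroxy and the chloro enter together, so the compounds shown leave open which of them matters. A plain 2-hydroxyphenyl group at this place would separate the two.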